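Changing the Terminal Amine on a Shared Core

This account rests on a few compounds, and the source may have more. Where it says the series, first, only, none or still open, it means among the compounds named here.

Compound 1 `O=c1cc(-c2ccccc2)oc2cc(OCc3ccccc3)c(OCCCN3CCCCC3)c(O)c12`: 2200 nM
Compound 2 `O=c1cc(-c2ccccc2)oc2cc(OCc3ccccc3)c(OCCCN3CCCC3)c(O)c12`: 4200 nM

Both compounds were tested in a functional assay on HepG2 cells (Homo sapiens) for antiproliferative activity, read by MTT assay, with a stated time of 48 h; on this read-out lower numbers stand for stronger inhibition and higher numbers for weaker inhibition. On the two numbers shown, compound 2 carries the higher one, but the only step recorded, a 1.9-fold higher number from compound 1 to compound 2 (0.28 log units; within the scatter), lies within the scatter, so the two compounds cannot be ordered with confidence.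

Compound 3 `CN1CCN(CCCCOc2c(OCc3ccccc3)cc3oc(-c4ccccc4)cc(=O)c3c2O)CC1` has not yet been measured. It differs from compound 2 at one place: (4-methylpiperazin-1-yl)methyl in place of pyrrolidin-1-yl on a saturated chain carbon, three bonds along the chain from an oxygen on an aromatic ring. Among the measured compounds shown here, the one measured step that bears on this position is the exchange of the terminal ring in a 1.9-fold higher number from compound 1 to compound 2 (0.28 log units; within the scatter), which produced no change beyond the scatter. The new change also alters the terminal amine and lengthens the chain by one carbon, but nothing in the measured pair suggests that this region drives potency. Compound 3 is therefore expected to show no step beyond the scatter, a 1.2-fold lower number from compound 2 to compound 3 (0.08 log units; within the scatter). The estimate for compound 3 is 3500 nM, with a range from 1400 nM to 9000 nM.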

Compound 3, half-maximal inhibitory concentration: 2500 nM
The estimate for compound 3 lay 1.4-fold (0.15 log units) above the measured number; measured number inside the range.
By their numbers in this assay, from the lowest: compounds 1, 3 and 2 (each within the scatter of the next).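

In this assay, (4-methylpiperazin-1-yl)methyl in place of pyrrolidin-1-yl on a saturated chain carbon, three bonds along the chain from an oxygen on an aromatic ring, gives a step within the scatter (a 1.7-fold lower number from compound 2 to compound 3 (0.23 log units; within the scatter)), and the same group in place of piperidin-1-yl does too (a 1.1-fold higher number from compound 1 to compound 3 (0.06 log units; within the scatter)). The earlier pair had covered only the exchange of one terminal ring for another on a propyl chain, whereas these steps show that a larger change, to 4-(4-methylpiperazin-1-yl)butyl, also leaves the number within the scatter of both earlier compounds, so the three cannot be ordered on this read-out. Nothing at hand offers a reason for this result.

From the compounds shown here alone, what stays open is whether the longer chain and the methylpiperazine ring each leave the number unchanged on their own, or whether 4-(pyrrolidin-1-yl)butyl would read differently from 3-(pyrrolidin-1-yl)propyl. Going by these compounds, it is also open whether a morpholin-4-yl group, an open-chain dimethylamino group or a carboxylic acid at the end of the chain would give a step beyond the scatter.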